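The compounds below may be only part of what the source reports. "The series", "measured", "known", "first", "only" and "open" are said of these compounds alone.

Values so far in a physicochemical assay for lipophilicity, at pH 7.4; on this read-out lower numbers stand for lower lipophilicity and higher numbers for higher lipophilicity:
- compound 1 `CNc1ccc(C#Cc2ccc(OCCOCCF)cc2)cc1`: 3.48
- compound 2 `CNc1ccc(C#Cc2ccc(OCCOCCOCCF)cc2)cc1`: 3.07
- compound 3 `CN(C)c1ccc(C#Cc2ccc(OCCOCCF)cc2)cc1`: 3.12

Compound 3, at 3.12, lies within the scatter of compound 2, at 3.07. Its gap to compound 1 is beyond the scatter, with the measured step being a number 0.36 log units lower from compound 1 to compound 3 (beyond the scatter).

Still unmeasured is compound 4 `CN(C)c1ccc(C#Cc2ccc(OCCOCCOCCF)cc2)cc1`. It differs from compound 3 by 2-fluoroethoxy in place of fluoro on a saturated chain carbon, two bonds along the chain from an oxygen on a saturated carbon.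

One measured step makes the same exchange: a number 0.41 log units lower from compound 1 to compound 2 (beyond the scatter). It is modest and beyond the scatter. The other measured step, a number 0.36 log units lower from compound 1 to compound 3 (beyond the scatter), is methyl in place of hydrogen on a nitrogen on an aromatic ring. That methyl is present in both compound 3 and compound 4, so this step sets the starting point and does not add to the change. Going by the values given here, no measured pair shows whether the chain exchange gives the same step with that methyl present, so the expectation rests on a single precedent.

A modest fall of similar size is therefore expected in this assay. The expected step is a number 0.37 log units lower from compound 3 to compound 4 (beyond the scatter). For compound 4 the estimated value is 2.75, with an expected range of 2.45 to 3.05.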

Compound 4, partition coefficient: 3.18
Compound 4: the middle estimate sits 0.43 log units below what was measured; the measured number lies above the stated range.
By their numbers in this assay, from the lowest: compounds 2, 3, 4 and 1 (each within the scatter of the next, the first and the last beyond it).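

In this assay, 2-fluoroethoxy in place of fluoro on a saturated chain carbon, two bonds along the chain from an oxygen on a saturated carbon, does not give a fixed step: with the methyl present on the nitrogen the result is a number 0.06 log units higher from compound 3 to compound 4 (within the scatter), against a number 0.41 log units lower from compound 1 to compound 2 (beyond the scatter) without it. The methyl shows the same dependence in reverse, with a number 0.11 log units higher from compound 2 to compound 4 (within the scatter) on the longer chain, against a number 0.36 log units lower from compound 1 to compound 3 (beyond the scatter) on the shorter one, so in this set of four compounds each change gives a step beyond the scatter only where the other is absent. No measurement on hand accounts for this dependence.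

From the compounds shown here alone, this rests on a single set of four compounds and one read-out, so it remains open whether the same dependence holds for a longer chain carrying a further 2-fluoroethoxy unit, or for a hydroxyl in place of the end fluoro. Going by these compounds, it is also open whether an ethyl group on the nitrogen, or an unsubstituted amine there, would change the size of the chain step.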